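Aryl variation in the series: from compound 3 to compound 4

The source may report more compounds than this note shows. Statements on the series, on what has been measured and on what is new or still open speak of the compounds shown alone.

Going by the values given here, compound 3 `CCC1=C(O)c2c(oc(-c3ccc(C)c(Cl)c3)cc2=O)C(CC)(CC)C1=O` gives 2.15 uM in a functional assay on KBVIN cells (Homo sapiens) for antiproliferative activity, read by sulforhodamine B assay, with a stated time of 3 days (on this read-out higher numbers stand for an effect only at larger amounts of compound and lower numbers for an effect already at smaller amounts), the lowest of the three numbers measured so far. Compound 2 `CCC1=C(O)c2c(oc(-c3ccccc3OC)cc2=O)C(CC)(CC)C1=O` gives 3.26 uM, and the two lie within the scatter of each other; compound 1 `CCC1=C(O)c2c(oc(-c3ccc(CBr)cc3)cc2=O)C(CC)(CC)C1=O` gives 27.9 uM, with a 13-fold lower number from compound 1 to compound 3 (1.11 log units; beyond the scatter) and an 8.6-fold lower number from compound 1 to compound 2 (0.93 log units; beyond the scatter). Compound 4 `CCC1=C(O)c2c(oc(-c3cc(C)ccc3C)cc2=O)C(CC)(CC)C1=O` carries 2,5-dimethylphenyl in place of 3-chloro-4-methylphenyl on an aromatic carbon. Among the compounds with values here, the step that bears most on this is a 1.5-fold lower number from compound 2 to compound 3 (0.18 log units; within the scatter), the one exchange so far of one substituted phenyl for another; the two larger steps both involve the 4-(bromomethyl)phenyl group and do not apply here. A step of a 1.2-fold higher number from compound 3 to compound 4 (0.07 log units; within the scatter) is therefore expected, nothing beyond the scatter. Compound 4 is estimated at 2.5 uM, within 1 uM to 6.5 uM.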

Compound 4, concentration for half-maximal effect: 3.41 uM
Compound 4: middle estimate off by 1.4-fold (0.13 log units), on the low side; the measured number falls inside the stated range.
By their numbers in this assay, from the lowest: compounds 3, 2 and 4 (each within the scatter of the next); then compound 1.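

The 2,5-dimethylphenyl group in place of 3-chloro-4-methylphenyl, at the aromatic carbon next to the ring oxygen, stays within the scatter in this assay (a 1.6-fold higher number from compound 3 to compound 4 (0.20 log units; within the scatter)), as it does in place of 2-methoxyphenyl (a 1.0-fold higher number from compound 2 to compound 4 (0.02 log units; within the scatter)). Three differently substituted phenyl groups thus share one band here, while the 4-(bromomethyl)phenyl group stays apart (an 8.2-fold lower number from compound 1 to compound 4 (0.91 log units; beyond the scatter)). No measurement available here explains either finding.

Going by these compounds, whether an amine or a carboxylic acid on the phenyl ring would stay in this band remains open. Also open, on these data alone, is whether the bromomethyl group itself or its place on the ring sets compound 1 apart.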